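This account rests on a few compounds, and the source may have more. Where it says the series, first, only, none or still open, it means among the compounds named here.

Measured compounds:
compound 1, `CCOC(=O)CC[C@H](NC(=O)c1ccc(CNc2ccc3nc(N)nc(N)c3c2)cc1)C(=O)OCC`: 7.54
compound 2, `Cc1cccc2nc(N)nc(N)c12`: 6.09
compound 3, `CCOC(=O)CC[C@H](NC(=O)c1ccc(CNc2ccc3nc(N)nc(O)c3c2)cc1)C(=O)OCC`: 6.24

The three measured compounds were tested in an assay for inhibition of Dihydrofolate reductase (Homo sapiens); a lower number here means a less potent compound, a higher number a more potent compound, by a factor of ten per unit of this negative logarithm. Compound 1 gives 7.54 and is the highest of the three numbers. Compound 3 is its direct partner: the only difference between them is hydroxy in place of amino on an aromatic carbon, and the step is a number 1.30 log units lower from compound 1 to compound 3 (beyond the scatter). Compound 2 gives 6.09 and has the lowest number; it lies within the scatter of compound 3, so no order can be read between those two, while the gap to compound 1 is beyond the scatter. Compound 2 carries a much smaller core than compound 1; the difference between the two cores is not broken down here.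

Compound 4, `Cc1cccc2nc(N)nc(O)c12`, has not been measured. It stands to compound 2 as compound 3 stands to compound 1, with hydroxy in place of amino on an aromatic carbon. The place descriptions of the two changes agree word for word, so this is the same change made on a second, smaller core. Only one measured instance of the change exists, and whether it carries over to the smaller core is not shown by any other pair.

Resting on the single step seen from compound 1 to compound 3, compound 4 is expected to fall by a number 1.19 log units lower from compound 2 to compound 4 (beyond the scatter) from compound 2. Compound 4 is therefore estimated at 4.9 in this assay, with a range of 4.2 to 5.6.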

Compound 4, logarithm of the reciprocal of the active concentration, log(1/C): 4.8
The estimate for compound 4 lay 0.10 log units above the measured number, and the stated range covers the measured number.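

In this assay, hydroxy in place of amino on an aromatic carbon of the smaller core leaves the reading a number 1.29 log units lower from compound 2 to compound 4 (beyond the scatter), so the change is large on this core as well. Set beside the earlier step on the core of compound 1, the size of the change shows no difference that can be told apart, even though compound 2 carries a much smaller core than compound 1: the same change on two cores in this assay, a number 1.30 log units lower (beyond the scatter) from compound 1 to compound 3 and a number 1.29 log units lower (beyond the scatter) from compound 2 to compound 4, 0.01 log units apart, within the scatter of two such steps. This shows that the step carried over between these two cores in this one assay, but two pairs do not establish a rule for other cores in the series, and they do not show why the number falls by so similar an amount.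

The compounds shown leave open what other groups would do in the same place, such as a methoxy group, a thiol or a methylamino group, since hydroxy is the only replacement for amino seen here. They also leave open whether the step would keep its size on a core of compound 1 that carries free carboxylic acids in place of the ethyl esters, or when hydroxy replaces the other amino group.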